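From 2-hydroxyethyl to 3-hydroxypropyl on compound 1

The source may report more compounds than this note shows. Statements on the series, on what has been measured and on what is new or still open speak of the compounds shown alone.

Among the measured compounds shown here, in a functional assay on MCF7 cells (Homo sapiens) for inhibition, read by MTT assay, with a stated time of 4 days (a lower number here means a stronger inhibitor, a higher number a weaker inhibitor), compound 1 (`COc1cc(NC(C)CCCNC(=O)NNC(=O)NCCO)c2ncccc2c1`) gives 13000 nM, the lower of the two actual numbers so far. Compound 3 (`O=C(NC(c1ccccc1)c1ccc(Cl)cc1)n1nnc2ccccc21`) gives 42000 nM, higher than compound 1 by more than the usual scatter. For compound 2 (`O=C(NC(c1ccccc1)c1ccc(Cl)cc1)NC(c1ccccc1)c1ccc(Cl)cc1`) the result is only a limit, > 100000 nM.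

Compound 4 (`COc1cc(NC(C)CCCNC(=O)NNC(=O)NCCCO)c2ncccc2c1`) keeps the core of compound 1 and differs by hydroxymethyl in place of hydroxy on a saturated chain carbon, two bonds along the chain from an amide-type nitrogen. For the measured compounds named here, no measured pair shows this change. The expected step is a 1.2-fold higher number from compound 1 to compound 4 (0.06 log units; within the scatter) in this assay, none beyond the scatter. Compound 4 is estimated at 15000 nM, with an expected range of 6000 nM to 40000 nM.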

Compound 4, half-maximal inhibitory concentration: 13000 nM
Beside the measured number, compound 4's estimate is 1.2-fold (0.06 log units) above it; low and high end bracket the measured number.
By their numbers in this assay, from the lowest: compounds 1 and 4 (each within the scatter of the next); then compound 3. At a limit, above all of these: compound 2.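

The change from 2-hydroxyethyl to 3-hydroxypropyl gives no change at the digits printed from compound 1 to compound 4 (within the scatter) in this assay. This first one-place comparison in the series shows that, on a saturated chain carbon two bonds along the chain from an amide-type nitrogen, the chain end can be extended with its hydroxy kept and the number holds. Nothing measured here points to a cause for this flat step.

On these data alone, a longer chain such as 4-hydroxybutyl remains open, as does an amine or a carboxylic acid in place of the terminal hydroxy. As far as these compounds go, whether changes elsewhere on the core of compound 1 are equally flat also stays open.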